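Azole replacement on the saturated chain carbon, EP3 series

A few compounds are considered here, and "the series" means these few. Any claim that something is new, unique, unknown or untested is made for them only; others in the source may bear on it.

Measured so far:
compound 1 `CC(C)C(Cc1nnc[nH]1)c1ccc(-c2ccc3cccc(F)c3c2)[nH]c1=O` — 17 nM
compound 2 `CC(C)C(c1ncc[nH]1)c1ccc(-c2ccc3cccc(F)c3c2)[nH]c1=O` — 33 nM

Among the compounds with values here, in a functional assay on CHO cells for antagonist activity at prostaglandin E2 receptor EP3 subtype (Homo sapiens), read by cAMP accumulation (on this read-out lower numbers stand for stronger inhibition and higher numbers for weaker inhibition), compound 2 gives the highest of the two numbers; its only neighbour, compound 1, sits a 1.9-fold higher number from compound 1 to compound 2 (0.29 log units; within the scatter) away, a gap within the scatter, so no order between the two can be read.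

Compound 3 `CC(C)C(Cc1nnn[nH]1)c1ccc(-c2ccc3cccc(F)c3c2)[nH]c1=O` is not yet measured. The change from compound 2 is (1H-tetrazol-5-yl)methyl in place of 1H-imidazol-2-yl on a saturated chain carbon bound to an aromatic carbon and a saturated chain carbon. Within the data shown here, the one measured step that bears on it is the exchange of two azoles at the same place, a 1.9-fold higher number from compound 1 to compound 2 (0.29 log units; within the scatter), which stayed within the scatter; compound 1 carries a methyl-linked azole like the one that enters in compound 3. A step of comparable size, toward a lower number, is therefore expected, a 1.7-fold lower number from compound 2 to compound 3 (0.22 log units; within the scatter), though one that may well fall inside the scatter. For compound 3 the estimate is 20 nM, with a range from 8 nM to 50 nM.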

Compound 3, half-maximal inhibitory concentration: 134 nM
Compound 3: the middle estimate sits 6.7-fold (0.83 log units) below what was measured; the whole stated range lies below it.
By their numbers in this assay, from the lowest: compounds 1 and 2 (each within the scatter of the next); then compound 3.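

In this assay, the azole ring on this saturated chain carbon now proves to matter: with the methyl link kept, 1H-tetrazol-5-yl in place of 4H-1,2,4-triazol-3-yl gives a 7.9-fold higher number from compound 1 to compound 3 (0.90 log units; beyond the scatter), a step beyond the scatter, which the first azole exchange did not show. The step of a 4.1-fold higher number from compound 2 to compound 3 (0.61 log units; beyond the scatter) is also beyond the scatter, but it changes both the ring and the link, so it cannot be assigned to either alone. No measurement on hand accounts for either step.

Going by these compounds, the effect of the methyl link alone stays open, as 1H-imidazol-2-yl appears only without it and the other two azoles only with it. Also open, on these data alone, is how a carboxylic acid, an amine or a longer chain ending in 1H-tetrazol-5-yl would read out at this position.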